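Oxadiazole in place of methylthiophene on the shared core

A few compounds are considered here, and "the series" means these few. Any claim that something is new, unique, unknown or untested is made for them only; others in the source may bear on it.

Among the measured compounds shown here, compound 2 `Cc1ccsc1-c1ccccc1NCC1=NCCN1` has the lowest number among the two compounds measured so far. In a functional assay for activation of Alpha-1A adrenergic receptor (Homo sapiens), read by calcium flux (on this read-out higher numbers stand for an effect only at larger amounts of compound and lower numbers for an effect already at smaller amounts), compound 2 gives 0.851 nM, while compound 1 `c1ccc(-c2cnco2)c(NCC2=NCCN2)c1` gives 17.4 nM; the step of a 20-fold lower number from compound 1 to compound 2 (1.31 log units; beyond the scatter) came with a 3-methylthiophen-2-yl in place of 1,3-oxazol-5-yl on an aromatic carbon. Compound 3 `Cc1nc(-c2ccccc2NCC2=NCCN2)no1` is not yet measured. It differs from compound 2 in one place: 5-methyl-1,2,4-oxadiazol-3-yl in place of 3-methylthiophen-2-yl on an aromatic carbon. For the measured compounds named here, the single step known here bears on it in reverse, since the ring that leaves is the one whose arrival in compound 2 brought the lower number, and the ring that enters is again a five-membered ring rich in hetero atoms, closer to that of compound 1. Compound 3 is therefore expected to move back toward the number of compound 1, with a step of an 18-fold higher number from compound 2 to compound 3 (1.25 log units; beyond the scatter). His estimate for compound 3 in this assay is 15 nM, within 3 nM to 70 nM.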

Compound 3, half-maximal effective concentration: 724 nM
Compound 3: middle estimate off by 48-fold (1.68 log units), on the low side, and the stated range ends below it.
By their numbers in this assay, from the lowest: compound 2; then compound 1; then compound 3.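

The ring at this place, on an aromatic carbon ortho to a group of 7 heavy atoms, does far more than fill space: in this assay, exchanging one ring of 6 heavy atoms for another of the same size gave an 850-fold higher number from compound 2 to compound 3 (2.93 log units; beyond the scatter). Nor do the two hetero-atom-rich rings behave alike, since the change between them gave a 42-fold higher number from compound 1 to compound 3 (1.62 log units; beyond the scatter), so a five-membered aromatic ring carrying oxygen and nitrogen does not by itself set the number. No measurement shown here accounts for either step.

The compounds shown leave open how much the ring methyl contributes on each ring, and whether the order of the ring atoms matters. A plain thiophen-2-yl, a 3-methyl-1,2,4-oxadiazol-5-yl or a phenyl ring at this place would begin to separate these questions.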